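The source may hold more compounds than are shown below. What is called first, only, known or untested is meant among the compounds shown, and "the series" means these compounds.

Measured compounds:
compound 1 `Cc1cccc(NC(=O)c2ccc(/N=N\c3c[nH]c4ccccc34)cc2)c1C` with 51600 nM
compound 2 `O=C(Nc1ccccc1[N+](=O)[O-])c1ccc(/N=N\c2c[nH]c3ccccc23)cc1` with 77900 nM
compound 3 `O=C(Nc1ccccc1Cl)c1ccc(/N=N\c2c[nH]c3ccccc23)cc1` with "not active" (no number reported), reported with no number

All three share one core and differ only in the ring attached to the amide nitrogen. In a functional assay on P388 cells (Mus musculus) for inhibition, read by MTT assay, with a stated time of 72 h (on this read-out lower numbers stand for stronger inhibition and higher numbers for weaker inhibition), compound 1 gives 51600 nM and compound 2 gives 77900 nM, so both are weak inhibitors, and a 1.5-fold higher number from compound 1 to compound 2 (0.18 log units; within the scatter) is a step within the scatter. Compound 3 stands apart: in this assay compound 3 was reported as not active, so no single number describes it, and it cannot be placed against the other two beyond being no stronger than them.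

Compound 4 `COc1ccccc1NC(=O)c1ccc(/N=N\c2c[nH]c3ccccc23)cc1` is the next compound. Its change from compound 3 is methoxy in place of chloro on an aromatic carbon, sitting ortho to a large group on an aromatic carbon of a six-membered aromatic ring of carbon only. For the measured compounds named here, the only measured step, from compound 1 to compound 2, also changes this ring and is within the scatter, which suggests that swapping groups here moves the numbers little. With compound 3 lacking a number, the expectation for compound 4 rests mainly on compound 1 and compound 2 being weak. Compound 4 is therefore estimated at 80000 nM, in a wide range from 20000 nM to 300000 nM, with a real chance that it too is reported only as not active.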

Compound 4, half-maximal inhibitory concentration: "not active" (no number reported)
Compound 4: no number reported; there is nothing to compare the estimate with.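

Compound 3 and compound 4 are both reported as not active, without a number, so no step can be read between them. No available evidence bears on this result. The compounds shown leave open how chloro and methoxy compare in size of effect on inhibition.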